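A few compounds are considered here, and "the series" means these few. Any claim that something is new, unique, unknown or untested is made for them only; others in the source may bear on it.

Three compounds share one core and differ only in what sits on one oxygen of an aromatic ring. Compound 1 `O=c1cc(-c2ccccc2)oc2cc(O)c(OCCCN3CCCCC3)c(O)c12` carries a hydrogen on that oxygen, and in a functional assay on BCG823 cells (Homo sapiens) for antiproliferative activity, read by MTT assay, with a stated time of 48 h (on this read-out higher numbers stand for weaker inhibition and lower numbers for stronger inhibition), compound 1 gives 60900 nM. Compound 2 `O=c1cc(-c2ccccc2)oc2cc(OCc3ccccc3)c(OCCCN3CCCCC3)c(O)c12` carries a benzyl group there, and compound 2 gives 4600 nM. Compound 3 `COc1cc2oc(-c3ccccc3)cc(=O)c2c(O)c1OCCCN1CCCCC1` carries a methyl group there, and compound 3 gives 25300 nM. On these numbers compound 3 stands second highest of the three: a 2.4-fold lower number from compound 1 to compound 3 (0.38 log units; beyond the scatter), a 13-fold lower number from compound 1 to compound 2 (1.12 log units; beyond the scatter), and a 5.5-fold higher number from compound 2 to compound 3 (0.74 log units; beyond the scatter). Compound 4 `COc1cc2oc(-c3ccccc3)cc(=O)c2c(O)c1OCCCCN1CCN(C)CC1` keeps the methyl group and instead changes the group on a saturated chain carbon, three bonds along the chain from an oxygen on an aromatic ring: (4-methylpiperazin-1-yl)methyl in place of piperidin-1-yl on a saturated chain carbon, three bonds along the chain from an oxygen on an aromatic ring. Among the measured compounds shown here, none of the measured steps touches that part of the chain, since all three measured compounds carry the same group there, so those steps give no direct guide. The change is therefore expected to bring no step beyond the scatter in this assay, which would mean a 1.0-fold lower number from compound 3 to compound 4 (0.01 log units; within the scatter). Compound 4 is estimated at 25000 nM, with a range from 8000 nM to 80000 nM.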

Compound 4, half-maximal inhibitory concentration: 53500 nM
Beside the measured number, compound 4's estimate is 2.1-fold (0.33 log units) below it, and the stated range covers the measured number.
By their numbers in this assay, from the lowest: compound 2; then compound 3; then compounds 4 and 1 (each within the scatter of the next).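

In this assay, among the compounds shown here, the far end of the chain turns out to matter: the earlier compounds all carry the same group there, whereas this swap gives a 2.1-fold higher number from compound 3 to compound 4 (0.33 log units; beyond the scatter) and so weakens inhibition. The direction differs from the ring oxygen, where a 2.4-fold lower number from compound 1 to compound 3 (0.38 log units; beyond the scatter) and a 13-fold lower number from compound 1 to compound 2 (1.12 log units; beyond the scatter) both went towards stronger inhibition. The swap changes two things at once, the ring and the added methyl link, so this single step cannot show which of them accounts for the rise.

The compounds shown leave open how a morpholin-4-yl or a dimethylamino group would read at the end of this chain, and whether the benzyl group of compound 2 would keep its lower number alongside (4-methylpiperazin-1-yl)methyl. Nothing measured here offers an explanation for the rise.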